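A Sulfanyl Side Chain in Place of an Amino Group

This account rests on a few compounds, and the source may have more. Where it says the series, first, only, none or still open, it means among the compounds named here.

compound 1 `Cc1ccc(C(=O)Nc2ccc(Cl)cc2C(N)=O)cc1` — 5.39 ug/mL
compound 2 `Cc1ccc(-c2nc(N)c3cc(Cl)ccc3n2)cc1` — 3.76 ug/mL
compound 3 `Cc1ccc(-c2nc3ccc(Cl)cc3c(=O)n2N)cc1` — 5.39 ug/mL

These three compounds have been measured in a functional assay on MCF7 cells (Homo sapiens) for antiproliferative activity, read by MTT assay, with a stated time of 48 h; on this read-out higher numbers stand for weaker inhibition and lower numbers for stronger inhibition. Compound 2 gives the smallest of the three numbers, yet compound 1 and compound 3 both stand within the scatter of it, so no order among them can be claimed.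

Compound 4 `Cc1ccc(-c2nc(SCCO)c3cc(Cl)ccc3n2)cc1` is not yet measured. It differs from compound 2 in one place: (2-hydroxyethyl)sulfanyl in place of amino on an aromatic carbon. Among the measured compounds shown here, no measured pair shows this change, so its effect in this assay cannot be read from a neighbour. The step is expected to be small, if anything toward a higher number, and not clearly beyond the scatter; the expected step is a 1.3-fold higher number from compound 2 to compound 4 (0.12 log units; within the scatter). Compound 4 is therefore estimated at 5 ug/mL, in a range from 2 ug/mL to 14 ug/mL.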

Compound 4, half-maximal inhibitory concentration: 3.76 ug/mL
Estimate against measurement, compound 4: 1.3-fold (0.12 log units) above; low and high end bracket the measured number.
By their numbers in this assay, from the lowest: compounds 2, 4, 1 and 3 (each within the scatter of the next).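

In this assay, (2-hydroxyethyl)sulfanyl in place of amino on the aromatic carbon next to the ring nitrogen gives no change at the digits printed from compound 2 to compound 4 (within the scatter). The earlier compounds shown here offered no single-place step at this carbon. This one shows that a side chain of 4 heavy atoms can stand here in place of 1 without a step beyond the scatter.

As far as these compounds go, whether a longer chain, a carboxylic acid or a dimethylamino group on this carbon would read the same stays open. So does the separate part played by the sulfur and the hydroxyl, and nothing measured here offers an explanation for the result.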